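The compounds below may be only part of what the source reports. "The series", "measured", "known", "first", "only" and "open" are said of these compounds alone.

Compound 3, with structure `CNC(=O)[C@@]12C[C@@H]1[C@@H](n1cnc3c(NC)nc(C#Cc4ncccn4)nc31)[C@H](O)[C@@H]2O`, gives 1.97 nM in an assay on CHO cells for displacement of a labelled ligand from adenosine receptor A3 (Homo sapiens), read by scintillation counting, with a stated time of 60 min; a higher number here means a weaker inhibitor, a lower number a stronger inhibitor. Among the three measured compounds it holds the second highest number: compound 1, `CNC(=O)[C@@]12C[C@@H]1[C@@H](n1cnc3c(NC)nc(C#Cc4ccccc4OC)nc31)[C@H](O)[C@@H]2O`, gives 0.77 nM, and compound 2, `CNC(=O)[C@@]12C[C@@H]1[C@@H](n1cnc3c(NC)nc(C#Cc4cccc(C(F)(F)F)c4)nc31)[C@H](O)[C@@H]2O`, gives 3.39 nM. The step of a 2.6-fold higher number from compound 1 to compound 3 (0.41 log units; beyond the scatter) lies beyond the scatter, whereas a 1.7-fold lower number from compound 2 to compound 3 (0.24 log units; within the scatter) lies within it.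

Compound 4, `CNC(=O)[C@@]12C[C@@H]1[C@@H](n1cnc3c(NC)nc(C#Cc4cnn(C)c4)nc31)[C@H](O)[C@@H]2O`, differs from compound 3 in one place: 1-methyl-1H-pyrazol-4-yl in place of pyrimidin-2-yl on a triple-bonded carbon. Both groups are small aromatic rings with two nitrogen atoms, so the change is a swap between close relatives at the same position.

Every measured step concerns the group on the triple-bonded carbon. The swap a 4.4-fold higher number from compound 1 to compound 2 (0.64 log units; beyond the scatter) was modest, a 2.6-fold higher number from compound 1 to compound 3 (0.41 log units; beyond the scatter) was modest, and a 1.7-fold lower number from compound 2 to compound 3 (0.24 log units; within the scatter) stayed within the scatter. The aryl group at this position therefore moves the number only mildly across the three compounds, with the 2-methoxyphenyl of compound 1 giving the lowest number.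

Compound 4 is expected to stay close to compound 3, the estimated step being a 1.3-fold higher number from compound 3 to compound 4 (0.10 log units; within the scatter), with no clear direction beyond the scatter. Compound 4 is estimated at 2.5 nM in this assay, in a range from 0.9 nM to 7 nM.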

Compound 4, inhibition constant: 2.34 nM
Compound 4: middle estimate off by 1.1-fold (0.03 log units), on the high side; low and high end bracket the measured number.
By their numbers in this assay, from the lowest: compound 1; then compounds 3, 4 and 2 (each within the scatter of the next).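

In this assay, moving from a six-membered to a five-membered aromatic ring on the triple-bonded carbon, with the heavy-atom and hydrogen-bond-acceptor counts unchanged, gave a 1.2-fold higher number from compound 3 to compound 4 (0.07 log units; within the scatter) and so did not separate these two groups. The 1-methyl-1H-pyrazol-4-yl group also stays level with the 3-(trifluoromethyl)phenyl group, with a 1.4-fold lower number from compound 2 to compound 4 (0.16 log units; within the scatter) in the same assay, which means that a five-membered ring, a six-membered ring with two nitrogens and a substituted phenyl all read alike here. Only the 2-methoxyphenyl group stands apart, with a 3.0-fold higher number from compound 1 to compound 4 (0.48 log units; beyond the scatter) as the third comparison, and compound 1 remains the strongest inhibitor of the four, though the spread across all these groups stays modest.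

The compounds shown leave open whether the methoxy group itself accounts for the lower number of compound 1, which a plain phenyl would test, and whether an amine or a carboxylic acid carried on the ring would stay within this narrow range. Nothing available here explains why these groups read alike or why the 2-methoxyphenyl group stands apart.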